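Replacing the Amide Substituent of Compound 2

The source may report more compounds than this note shows. Statements on the series, on what has been measured and on what is new or still open speak of the compounds shown alone.

Measured in an ADME assay on microsomes from liver (Mus musculus, strain CD-1) for metabolic stability, read by LC-MS, tested at 2 uM; on this read-out lower numbers stand for a shorter-lived compound and higher numbers for a longer-lived compound:
Compound 1 `CNC(=O)c1ccncc1Nc1cc(-c2ccc3ccn(C)c3c2)c2nccnc2c1`: 0.45 h
Compound 2 `CC(=O)N1CCOC(CNC(=O)c2ccncc2Nc2cc(-c3ccc4ccn(C)c4c3)c3nccnc3c2)C1`: 0.217 h

Compound 2, at 0.217 h, holds the lower of the two numbers in this assay. Compound 3 `CC(=O)N1CC(NC(=O)c2ccncc2Nc2cc(-c3ccc4ccn(C)c4c3)c3nccnc3c2)C1` differs from it in one place: 1-acetylazetidin-3-yl in place of (4-acetylmorpholin-2-yl)methyl on an amide-type nitrogen. The group still sits on the amide-type nitrogen, and it remains acetylated.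

For the measured compounds named here, only one measured step bears on this change: a 2.1-fold lower number from compound 1 to compound 2 (0.32 log units; beyond the scatter), which is modest but beyond the scatter. Going by the values given here, it came with 4-acetylmorpholin-2-yl taking the place of hydrogen on a saturated chain carbon, so it is only an indirect guide, since no measured compound carries the 1-acetylazetidin-3-yl group. A small rise that partly returns toward compound 1 therefore seems likely, though not one beyond the scatter. The expected size is a 1.4-fold higher number from compound 2 to compound 3 (0.14 log units; within the scatter). For compound 3 the estimated half-life is 0.3 h, with an expected range of 0.15 h to 0.6 h.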

Compound 3, half-life: 0.817 h
Compound 3: the middle estimate sits 2.7-fold (0.44 log units) below what was measured; measured number outside the range, above it.
By their numbers in this assay, from the lowest: compound 2; then compounds 1 and 3 (each within the scatter of the next).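

In this assay, exchanging the group on the amide-type nitrogen gives a 3.8-fold higher number from compound 2 to compound 3 (0.58 log units; beyond the scatter), so the shorter half-life seen with (4-acetylmorpholin-2-yl)methyl does not extend to every acetylated ring at this place. Set against methyl, the 1-acetylazetidin-3-yl group gives a 1.8-fold higher number from compound 1 to compound 3 (0.26 log units; within the scatter), a step within the scatter, so this place can carry an acetylated ring without the loss seen with the morpholine group. No measurement offered here accounts for the difference between the two acetylated rings.

The compounds shown do not separate the effect of ring size from that of the methyl link, which a 4-acetylmorpholin-2-yl group set directly on the nitrogen would address. They also leave open whether the acetyl matters, as an azetidine with a free amine would show.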